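This account rests on a few compounds, and the source may have more. Where it says the series, first, only, none or still open, it means among the compounds named here.

Measured compounds:
- compound 1, `CC(C)(C)[C@@H](O)C(=O)N1[C@@H]2C[C@@H]2C[C@H]1C(=O)NCc1cc(Cl)ccc1-n1cnnn1`: 54 mL.min-1.g-1
- compound 2, `CC(C)(C)[C@@H](O)C(=O)N1CSC[C@H]1C(=O)NCc1cc(Cl)ccc1-n1cnnn1`: 120 mL.min-1.g-1
- compound 3, `CCCC[C@@H](O)C(=O)N1N=CC[C@H]1C(=O)NCc1cc(Cl)ccc1-n1cnnn1`: < 12 mL.min-1.g-1

Three compounds that share the same right-hand portion of the molecule have been run in an ADME assay on liver for metabolic stability, with Liver microsome (Homo sapiens) as the target, read by LC-MS, using microsomes; a higher number here means faster removal of the compound, a lower number slower removal. Compound 1 gives 54 mL.min-1.g-1 in this assay. Compound 2 gives 120 mL.min-1.g-1 in this assay, a higher number that lies beyond the usual scatter of the measurement. Compound 3 returns no number in this assay but only a limit, (the limit of < 12 mL.min-1.g-1 in this assay, at which 1 of the 3 values shown sits). Among the two numbers actually reported, compound 1 therefore stands as the lower one, with compound 2 as its nearest neighbour.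

The next compound, compound 4, `CC(C)(C)C[C@@H](O)C(=O)N1[C@@H]2C[C@@H]2C[C@H]1C(=O)NCc1cc(Cl)ccc1-n1cnnn1`, has not yet been measured in this assay. It differs from compound 1 in one place: neopentyl in place of tert-butyl on a saturated chain carbon bound to a carbonyl carbon and an oxygen on a saturated carbon. Going by the values given here, no pair of measured compounds differing in one place is available, so the size of this step cannot be read from the data. The account expects the step from compound 1 to compound 4 in this assay to be small, if anything toward a somewhat higher number, and most likely within the scatter, giving a 1.3-fold higher number from compound 1 to compound 4 (0.11 log units; within the scatter). Compound 4 is accordingly estimated at 70 mL.min-1.g-1, with a range from 35 mL.min-1.g-1 to 140 mL.min-1.g-1.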

Compound 4, intrinsic clearance in microsomes: 71 mL.min-1.g-1
The estimate for compound 4 lay 1.0-fold (0.01 log units) below the measured number; low and high end bracket the measured number.
By their numbers in this assay, from the lowest: compounds 1, 4 and 2 (each within the scatter of the next, the first and the last beyond it). At a limit, below all of these: compound 3.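

In this assay, neopentyl in place of tert-butyl on a saturated chain carbon bound to a carbonyl carbon and an oxygen on a saturated carbon gives a 1.3-fold higher number from compound 1 to compound 4 (0.12 log units; within the scatter), so the two compounds cannot be told apart in this read-out. Going by these compounds alone, the earlier compounds differ from one another in more than one place and could say nothing about this position alone, whereas this pair, with the core of compound 1 held fixed, is the first to isolate it, and the swap of tert-butyl for neopentyl leaves no change beyond the scatter. Nothing else measured in this account bears on this pair, so the result stands without an explanation.

Going by these compounds, this single pair gives one step on one core, so it remains open whether the same swap would also stay within the scatter on the core of compound 2 or on the core of compound 3. On these data alone, it is equally open whether a longer chain, a cyclohexyl ring or an amine at this place would move the number beyond the scatter.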